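The source may hold more compounds than are shown below. What is called first, only, known or untested is meant among the compounds shown, and "the series" means these compounds.

Compound 1 `O=C(O)CC(NS(=O)(=O)c1ccccc1)c1ccccc1F`: > 100000 nM
Compound 2 `O=C(O)CC(NS(=O)(=O)c1ccc(C(F)(F)F)cc1)c1ccccc1F`: 55600 nM
Compound 3 `O=C(O)CC(NS(=O)(=O)c1cc(F)cc(F)c1)c1ccccc1F`: not yet measured

In a functional assay on MDA-MB-436 cells (Homo sapiens) for antiproliferative activity, read by MTT assay, with a stated time of 24 h (on this read-out lower numbers stand for stronger inhibition and higher numbers for weaker inhibition), compound 1 gives > 100000 nM, which is a limit of the assay and not a number. Compound 3 carries 3,5-difluorophenyl in place of phenyl on a sulfonyl sulfur. For the measured compounds named here, the only measured step that bears on this change is an at least 1.7-fold lower number from compound 1 to compound 2 (0.25 log units; that floor lies within the scatter), made by trifluoromethyl in place of hydrogen on an aromatic carbon. A small move towards a lower number is therefore expected, perhaps none beyond the scatter. The expected step is an at least 1.4-fold lower number from compound 1 to compound 3 (0.15 log units; that floor lies within the scatter). For compound 3 the estimated value is 70000 nM, with an expected range of 30000 nM to 140000 nM.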

Compound 3, half-maximal inhibitory concentration: 89300 nM
For compound 3 the middle estimate is 1.3-fold (0.11 log units) below the measured one, and the stated range covers the measured number.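

With 3,5-difluorophenyl in place of phenyl on a sulfonyl sulfur, this assay shows an at least 1.1-fold lower number from compound 1 to compound 3 (0.04 log units; that floor lies within the scatter). This change therefore gives a measured number, but the floor of the step stays within the scatter. The true size of the step cannot be read because its starting point is a limit of the assay and not a number: the limit of > 100000 nM in this assay, at which 1 of the 3 values shown sits.

The compounds shown leave open whether an amine or a methoxy group on this ring would move the number beyond the scatter. They also leave open how a single fluorine would compare with the two in compound 3.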